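The compounds below may be only part of what the source reports. "The series", "measured", "known", "first", "only" and "open" are said of these compounds alone.

Measured compounds in an assay on isolated protein (urine) for inhibition of Myeloperoxidase (Homo sapiens), with a stated time of 5 min; on this read-out higher numbers stand for weaker inhibition and lower numbers for stronger inhibition:
compound 1 `NCCSCCc1c[nH]c2ccc(F)cc12`, 4 nM
compound 2 `ONCCCc1c[nH]c2ccc(F)cc12`, 11 nM

Compound 2 stands at the highest of the two numbers in this assay; its nearest neighbour is compound 1, and the step of a 2.8-fold higher number from compound 1 to compound 2 (0.44 log units; beyond the scatter) lies beyond the scatter, so compound 1 is the stronger inhibitor of the pair.

Compound 3 `N#CSCCCc1c[nH]c2ccc(F)cc12` has not yet been measured. Compared with compound 2, the change is cyanosulfanyl in place of hydroxyamino on a saturated chain carbon, three bonds along the chain from an aromatic carbon. Within the data shown here, only one measured step bears on this position: a 2.8-fold higher number from compound 1 to compound 2 (0.44 log units; beyond the scatter), which shows that exchanging the group on this chain moved the number modestly, and that a sulfur-bearing chain end, as in compound 1, gave the lower number. Compound 3 restores a sulfur-bearing end but without the amine of compound 1 and without the donors of compound 2, so the direction is uncertain; a modest step in this assay, most likely downward, is expected, with a wide range.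

Compound 3 is therefore expected to give about 8 nM in this assay, between 2 nM and 35 nM, a step of a 1.4-fold lower number from compound 2 to compound 3 (0.14 log units; within the scatter) that is estimated rather than known.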

Compound 3, half-maximal inhibitory concentration: 5 nM
Estimate against measurement, compound 3: 1.6-fold (0.20 log units) above; the range from low to high includes it.
By their numbers in this assay, from the lowest: compounds 1 and 3 (each within the scatter of the next); then compound 2.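

In this assay, the new result shows that this position tolerates an end group with no hydrogen-bond donors: cyanosulfanyl in place of hydroxyamino, on a saturated chain carbon three bonds along the chain from an aromatic carbon, gives a 2.2-fold lower number from compound 2 to compound 3 (0.34 log units; beyond the scatter), a modest gain that goes beyond the scatter. It also shows that the amine of compound 1 is not required to reach its level, since a 1.3-fold higher number from compound 1 to compound 3 (0.10 log units; within the scatter) leaves compound 3 and compound 1 indistinguishable, even though (cyanosulfanyl)methyl and (2-aminoethyl)sulfanyl share little beyond a sulfur atom. Nothing available explains why either group behaves as it does.

As far as these compounds go, what remains open is whether sulfur itself goes with the lower numbers, as the only sulfur-free end here is hydroxyamino, so a plain amine, a carboxylic acid or a simple nitrile on the same chain would be needed to separate the sulfur from the rest of each group. A longer or shorter chain carrying the cyanosulfanyl group is also unaddressed, as is any change to the shared core.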